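This account rests on a few compounds, and the source may have more. Where it says the series, first, only, none or still open, it means among the compounds named here.

Measured compounds:
compound 1 `CC1=C(/C=C/C(=O)/C=C/c2ccc(Br)cc2)C(C)(C)CCC1` with 34500 nM
compound 2 `CC1=C(/C=C/C(=O)/C=C/c2ccccc2[N+](=O)[O-])C(C)(C)CCC1` with 44900 nM

Both numbers come from a functional assay on Hep cells (Homo sapiens) for cytotoxicity, read by sulforhodamine B assay, with a stated time of 48 h; on this read-out higher numbers stand for weaker inhibition and lower numbers for stronger inhibition. Compound 2 returns the higher of the two numbers, yet its gap to compound 1 is within the usual scatter of this assay, so the two compounds cannot be told apart on these data.

Compound 3 `CC1=C(/C=C/C(=O)/C=C/c2ccccc2Br)C(C)(C)CCC1` has not been measured. It differs from compound 2 in one place: bromo in place of nitro on an aromatic carbon. For the measured compounds named here, no measured pair in this set shows a step of this kind, so nothing in the data says how such an exchange shifts the read-out. Going by the values given here, the only guide is that compound 1, which also carries a bromo group on its aromatic ring, gives 34500 nM in this assay, close to compound 2.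

Compound 3 is therefore expected to sit near both measured compounds, with a step of a 1.2-fold lower number from compound 2 to compound 3 (0.07 log units; within the scatter) that stays within the scatter and in no clear direction. The estimate for compound 3 in this assay is 38000 nM, with a range from 18000 nM to 80000 nM.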

Compound 3, half-maximal inhibitory concentration: 16300 nM
Estimate against measurement, compound 3: 2.3-fold (0.37 log units) above; the whole stated range lies above it.
By their numbers in this assay, from the lowest: compound 3; then compounds 1 and 2 (each within the scatter of the next).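

In this assay, for the compounds shown here, bromo in place of nitro on an aromatic carbon, ortho to a large group, gives a 2.8-fold lower number from compound 2 to compound 3 (0.44 log units; beyond the scatter) and so provides the first readable exchange at this place, showing that the group held there bears on the number. The location of the bromo group also counts: 2-bromophenyl in place of 4-bromophenyl gives a 2.1-fold lower number from compound 1 to compound 3 (0.33 log units; beyond the scatter) on the same chain, a separation that compounds 1 and 2 could not provide, since their numbers lie within the scatter of each other. No measurement among these data speaks to what lies behind either step.

From the compounds shown here alone, the three compounds cover only bromo and nitro on this ring and only two locations for bromo, so it stays open whether the lower number of compound 3 is particular to bromo or would also appear with another group at the same aromatic carbon. A chloro group, a methoxy group or an amine there could fall near compound 3 or near compound 2, and these data cannot say which, nor what any change to the shared core would do.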